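Adding a second fluoro to compound 2

This account rests on a few compounds, and the source may have more. Where it says the series, first, only, none or still open, it means among the compounds named here.

- compound 1 `C=C(Br)C(=O)Nc1cccc(/C=C/C(=O)Nc2cccc3ccccc23)c1` gives 2800 nM
- compound 2 `C=C(Br)C(=O)Nc1cccc(/C=C/C(=O)Nc2ccc(F)cc2)c1` gives 13600 nM

In a functional assay on MCF7 cells (Homo sapiens) for inhibition, read by MTT assay, with a stated time of 72 h (a higher number here means a weaker inhibitor, a lower number a stronger inhibitor), compound 2 stands at 13600 nM as the higher of the two numbers, which makes it the weaker inhibitor, and its gap to compound 1 lies beyond the usual scatter. Compound 3 `C=C(Br)C(=O)Nc1cccc(/C=C/C(=O)Nc2ccc(F)c(F)c2)c1` keeps the shared core but goes from 4-fluorophenyl to 3,4-difluorophenyl, with fluoro in place of hydrogen on an aromatic carbon. Going by the values given here, no measured pair shows this change, so the data offer no direct guide, and no step beyond the scatter is expected in this assay here. The expected step of a 1.4-fold lower number from compound 2 to compound 3 (0.13 log units; within the scatter) is a modest one. For compound 3 the estimated value is 10000 nM (4500 nM to 21000 nM).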

Compound 3, half-maximal inhibitory concentration: 2690 nM
Estimate against measurement, compound 3: 3.7-fold (0.57 log units) above, outside the stated range (below it).
By their numbers in this assay, from the lowest: compounds 3 and 1 (each within the scatter of the next); then compound 2.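

In this assay, a single added fluoro, turning 4-fluorophenyl into 3,4-difluorophenyl, gives a 5.1-fold lower number from compound 2 to compound 3 (0.70 log units; beyond the scatter) and so a stronger inhibitor. Going by these compounds alone, this is the first measured pair to isolate one change, and it shows that one extra heavy atom at this ring position can move the result beyond the usual scatter. Nothing measured here explains the step.

From the compounds shown here alone, whether a chloro, methyl or methoxy group at the same place would act like fluoro remains open. So does whether this fluoro would give a similar step without the existing fluoro on the ring.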